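Acetyl for Phenyl on the Pyrazoline Nitrogen of Compound 1

The source may hold more compounds than are shown below. What is called first, only, known or untested is meant among the compounds shown, and "the series" means these compounds.

Compound 1 `COc1ccc(C2CC(c3ccc(NC(=O)c4cc(Cl)ccc4OC)cc3)=NN2c2ccccc2)cc1` was tested in a functional assay on the whole organism (strain albino) with Rattus norvegicus as the target, read by paw edema, with stated times of 1 h and 4 h, at a dose of 25 mg/kg by the oral route (on this read-out higher numbers stand for a stronger effect at the one dose given and lower numbers for a weaker effect), where compound 1 gives 94.8%. For the measured compounds named here, its only measured companion is compound 2 `COc1ccc(Cl)cc1C(=O)Nc1ccc(C2=NN(c3ccccc3)C(c3ccccc3[N+](=O)[O-])C2)cc1`, which in this assay gives 80.2%; the single measured step, a number 14.6 percentage points lower from compound 1 to compound 2 (beyond the scatter), concerns a change at a saturated ring carbon. Among the two numbers available, compound 1 stands highest, and compound 2 lies below it by a step beyond the scatter.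

Compound 3 `COc1ccc(C2CC(c3ccc(NC(=O)c4cc(Cl)ccc4OC)cc3)=NN2C(C)=O)cc1` has not been measured. It differs from compound 1 as follows: acetyl in place of phenyl on an amine nitrogen in a ring. Going by the values given here, no measured step touches the amine nitrogen in the ring, so the step from compound 1 to compound 2 does not bear on this change, and the data give no direct guide to its size or direction.

Without such guidance, compound 3 is expected to give 72% in this assay, within a range from 50% to 92%, which as a step means a number 22.8 percentage points lower from compound 1 to compound 3 (beyond the scatter) and is counted as an estimate only.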

Compound 3, a percentage reported as activity, at one dose (the size of the read-out at that dose, not a potency): 86%
Estimate against measurement, compound 3: 14 percentage points below; the measured number falls inside the stated range.
By their numbers in this assay, from the lowest: compounds 2, 3 and 1 (each within the scatter of the next, the first and the last beyond it).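

For the compounds shown here, the first reading at this position, the amine nitrogen in the ring, comes from this assay: acetyl in place of phenyl gives a number 8.8 percentage points lower from compound 1 to compound 3 (within the scatter), so this change does not separate the two compounds here. A group with no ring can therefore stand on this nitrogen in place of the six-membered aromatic ring without a difference beyond the scatter at the one dose given, whereas the earlier step at the saturated ring carbon did lie beyond it. No measurement shown here offers an explanation for this result.

Going by these compounds, it remains open how other groups on this nitrogen would read, such as a methyl, a formyl, a longer acyl chain or a benzoyl. Also open, on these data alone, is whether acetyl would give a similar reading with 2-nitrophenyl on the saturated ring carbon.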